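From compound 2 to compound 4: a carbonyl substituent swap

The compounds below may be only part of what the source reports. "The series", "measured", "known", "first", "only" and "open" are said of these compounds alone.

- compound 1 `O=S(=O)(Nc1ccc(-c2nc3cc(NS(=O)(=O)c4cccc(C(F)(F)F)c4)ccc3o2)cc1)c1cccc(C(F)(F)F)c1`: 14000 nM
- compound 2 `COc1ccc(S(=O)(=O)Nc2ccc3oc(-c4ccc(NC(=O)c5ccc(Cl)s5)cc4)nc3c2)cc1`: 5400 nM
- compound 3 `O=S(=O)(Nc1ccc(-c2nc3cc(NS(=O)(=O)c4cccc5ccccc45)ccc3o2)cc1)c1cccc2ccccc12`: 20000 nM

In a functional assay on HCT-116 cells (Homo sapiens) for cytotoxicity, read by resazurin assay, with a stated time of 48 h (on this read-out higher numbers stand for an effect only at larger amounts of compound and lower numbers for an effect already at smaller amounts), compound 2 has the lowest of the three numbers, and compound 1 and compound 3 both lie higher, beyond the scatter. Compound 4 `COc1ccc(S(=O)(=O)Nc2ccc3oc(-c4ccc(NC(=O)C5CCN(C(C)=O)CC5)cc4)nc3c2)cc1` carries 1-acetylpiperidin-4-yl in place of 5-chlorothiophen-2-yl on a carbonyl carbon. For the measured compounds named here, no measured pair differs in one place, so the three values offer only a loose guide. The expectation starts from compound 2 at 5400 nM and stays within the spread of the three values, in which compound 3 gives 20000 nM. The expected change is a 2.2-fold higher number from compound 2 to compound 4 (0.35 log units; beyond the scatter), a moderate move to a higher number, beyond the scatter. Compound 4 is estimated at 12000 nM, with an expected range of 5000 nM to 30000 nM.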

Compound 4, half-maximal effective concentration: 15000 nM
Beside the measured number, compound 4's estimate is 1.3-fold (0.10 log units) below it, and the stated range covers the measured number.
By their numbers in this assay, from the lowest: compound 2; then compounds 1, 4 and 3 (each within the scatter of the next).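

In this assay the swap on the carbonyl carbon gives a 2.8-fold higher number from compound 2 to compound 4 (0.44 log units; beyond the scatter) and is the only one-place step shown. It shows that the number at this position depends on the group carried there, with 1-acetylpiperidin-4-yl on the higher side of 5-chlorothiophen-2-yl. Nothing available explains the step.

As far as these compounds go, it remains open whether the step follows from losing the 5-chlorothiophen-2-yl or from gaining the 1-acetylpiperidin-4-yl. A plain thiophen-2-yl without the chlorine, or a piperidin-4-yl with a free ring amine, would help to separate the two.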